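Swapping the sulfonyl aryl on a weak kallikrein-7 inhibitor

This account rests on a few compounds, and the source may have more. Where it says the series, first, only, none or still open, it means among the compounds named here.

Of the compounds shown here, three sharing one core have been measured in an assay on isolated protein for inhibition of kallikrein-7 (Homo sapiens), read by fluorescence, with stated times of 10 min and 30 min; on this read-out lower numbers stand for stronger inhibition and higher numbers for weaker inhibition. Compound 1 `Cc1ccc(S(=O)(=O)n2cc(C3CNC(C(C)C)=N3)c3ccccc32)cc1` gives 70000 nM. Compound 2 `CC1=NC(c2cn(S(=O)(=O)c3ccc(C)cc3)c3ccccc23)CN1` gives 10000 nM, the lowest of the two numbers recorded. Compound 3 `Cc1ccc(S(=O)(=O)n2cc(C3CNC(C4CCCCC4)=N3)c3ccccc32)cc1` reaches only the assay limit of > 100000 nM. The measured steps all change the group on the carbon with a double bond to nitrogen: a 7.0-fold lower number from compound 1 to compound 2 (0.85 log units; beyond the scatter), an at least 1.4-fold higher number from compound 1 to compound 3 (0.15 log units; that floor lies within the scatter) and an at least 10-fold higher number from compound 2 to compound 3 (1.00 log units; beyond the scatter), the last ending at the limit (the limit of > 100000 nM in this assay, at which 1 of the 3 values shown sits). Compound 4 `CC1=NC(c2cn(S(=O)(=O)c3cccc(Cl)c3)c3ccccc23)CN1` differs from compound 2 elsewhere: 3-chlorophenyl in place of 4-methylphenyl on a sulfonyl sulfur. Within the data shown here, none of the measured steps touches that position, so they give no direct size for this change, and there is no basis to expect a shift beyond the scatter in this assay in either direction. Compound 4 is therefore estimated at 10000 nM, with a range from 3000 nM to 35000 nM. The step this expectation implies is no change at the digits printed from compound 2 to compound 4 (within the scatter).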

Compound 4, half-maximal inhibitory concentration: > 30000 nM
Compound 4: a limit, no number (the forecaster's own chance of this, stated with the estimate: 15%); at least 3.0-fold (0.47 log units) between middle value and limit.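

Among these compounds, with 3-chlorophenyl in place of 4-methylphenyl on a sulfonyl sulfur, this assay shows an at least 3.0-fold higher number from compound 2 to compound 4 (0.47 log units; beyond the scatter) and so gives the first measured sign that this position, untouched by the earlier steps, bears on the read-out. The change runs towards weaker inhibition, even though both groups have the same count of heavy atoms and one six-membered aromatic ring of carbon only. Compound 4 gives > 30000 nM, which is a limit and not a number, so the step has a floor but no full size: the limit of > 30000 nM in this assay, at which 1 of the 4 values shown sits.

The compounds shown leave open how a plain phenyl, a fluorophenyl or an aminophenyl group on the sulfonyl sulfur would read, and so whether the chlorine or the loss of the methyl counts here. They also leave open whether this change would read the same with isopropyl in place of the methyl on the carbon with a double bond to nitrogen.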